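The compounds below may be only part of what the source reports. "The series", "measured", "known", "first", "only" and "open" are said of these compounds alone.

In a functional assay on MCF7 cells (Homo sapiens) for inhibition, read by MTT assay, with a stated time of 48 h (a higher number here means a weaker inhibitor, a lower number a stronger inhibitor), compound 1 (`CCOC(=O)C1=C(N/C=N/c2cccnc2Cl)Nc2[nH]nc(C)c2C1c1ccc(N(C)C)cc1`) gives 4180 nM while compound 2 (`CCOC(=O)C1=C(NN=C(C(C)=O)C(C)=O)Nc2[nH]nc(C)c2C1c1ccc(N(C)C)cc1`) gives 9740 nM as the higher of these two numbers. For compound 3 (`CCOC(=O)C1=C(N/N=C(\c2ccc([N+](=O)[O-])cc2)N2CCN(c3ccc(F)cc3)CC2)Nc2[nH]nc(C)c2C1c1ccc(N(C)C)cc1`) the assay reports only a limit, > 100000 nM and no number. Compound 4 (`CCOC(=O)C1=C(N/N=C(/C#N)C(=O)OCC)Nc2[nH]nc(C)c2C1c1ccc(N(C)C)cc1`) differs from compound 2 by one group on an amine nitrogen (a group of 9 heavy atoms (5 carbon, 2 nitrogen, 2 oxygen; no ring) in place of a group of 8 heavy atoms (5 carbon, 1 nitrogen, 2 oxygen; no ring), on an amine nitrogen). For the measured compounds named here, only one measured step bears on that place, a 2.3-fold higher number from compound 1 to compound 2 (0.37 log units; beyond the scatter) and modest in size, and it swaps in a ring-bearing group, which neither compound 2 nor compound 4 carries. No step beyond the scatter is therefore expected in this assay for this change between two open-chain groups. The expected step is a 1.2-fold lower number from compound 2 to compound 4 (0.09 log units; within the scatter) and no more. Compound 4 is estimated at 8000 nM within an expected range of 2500 nM to 30000 nM for the measurement.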

Compound 4, half-maximal inhibitory concentration: 35600 nM
Beside the measured number, compound 4's estimate is 4.5-fold (0.65 log units) below it; the whole stated range lies below it.
By their numbers in this assay, from the lowest: compound 1; then compound 2; then compound 4. At a limit, above all of these: compound 3.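

In this assay a swap between two open-chain groups on this amine nitrogen does register: it gives a 3.7-fold higher number from compound 2 to compound 4 (0.56 log units; beyond the scatter) and so moves the number beyond the scatter. Replacing the ring-bearing group with the same entering group gives an 8.5-fold higher number from compound 1 to compound 4 (0.93 log units; beyond the scatter) as the widest numeric step seen at this position. Nothing measured here accounts for either step. The compounds shown leave open whether the nitrile alone carries the step, and how a simple amine or a carboxylic acid in this group would read.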